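A few compounds are considered here, and "the series" means these few. Any claim that something is new, unique, unknown or untested is made for them only; others in the source may bear on it.

Among the measured compounds shown here, in a functional assay on MDA-MB-231 cells (Homo sapiens) for cytotoxicity, read by MTT assay, with a stated time of 72 h, tested at 1 uM, in the absence of a further agent (a higher number here means a weaker effect of the compound at the concentration tested, a lower number a stronger effect), compound 2 `CCCNC1=Nc2ccc(Cl)cc2C(C)(C)C1` gives 90.7%, the higher of the two numbers measured so far. For the measured compounds named here, compound 1 `CC1(C)CC(N)=Nc2ccc(Cl)cc21` gives 80.5% in this assay, and the single measured step, a number 10.2 percentage points higher from compound 1 to compound 2 (beyond the scatter), came with propyl in place of hydrogen on an amine nitrogen. Compound 3 `CC1(C)CC(NCCCCO)=Nc2ccc(Cl)cc21` is the next compound, and it differs from compound 2 by hydroxymethyl in place of hydrogen on a saturated chain carbon, three bonds along the chain from an amine nitrogen. Going by the values given here, the one measured step touches the amine nitrogen itself, not the far end of the chain, so it bears only loosely on this change; it was modest, and nothing measured shows a hydroxymethyl entering a chain. In this assay the step of a number 1.7 percentage points lower from compound 2 to compound 3 (within the scatter) is therefore expected to stay within the usual scatter, with no clear direction. Compound 3 is estimated to give 89% in this assay, within a range from 75% to 100%.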

Compound 3, a percentage reported as activity, at one concentration (the size of the read-out at that concentration, not a potency): 87.6%
Compound 3: middle estimate off by 1.4 percentage points, on the high side; the range from low to high includes it.
By their numbers in this assay, from the lowest: compounds 1, 3 and 2 (each within the scatter of the next, the first and the last beyond it).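

In this assay, adding hydroxymethyl on a saturated chain carbon, three bonds along the chain from an amine nitrogen, shows no clear effect at this one concentration (with a number 3.1 percentage points lower from compound 2 to compound 3 (within the scatter)). The 4-hydroxybutyl group on the amine nitrogen also stays within the scatter (with a number 7.1 percentage points higher from compound 1 to compound 3 (within the scatter)), whereas the propyl step from compound 1 lies beyond it, so only propyl gives a read-out that can be told apart from that of compound 1. Nothing available explains these numbers.

As far as these compounds go, whether an amine or a carboxylic acid in place of the hydroxymethyl would give a different read-out remains open. So does whether a longer chain would separate from compound 1, and a single concentration cannot show how potency differs among these compounds.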